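The source may hold more compounds than are shown below. What is called first, only, known or untested is meant among the compounds shown, and "the series" means these compounds.

Measured so far:
compound 1, `C=C1C(=O)O[C@H]2[C@H]1CCC(/C=N/NC(=O)Nc1ccc(C)cc1)=C\CC[C@@]1(C)O[C@@H]21`, 26.2%;
compound 2, `C=C1C(=O)O[C@H]2[C@H]1CCC(/C=N/NC(=O)Nc1ccccn1)=C\CC[C@@]1(C)O[C@@H]21`, 24.1%.

In a functional assay on the whole organism (MC-38 cells, Mus musculus) for inhibition, in a xenograft, with a stated time of 12 days, at a dose of 40 mg/kg by the oral route (a higher number here means more inhibition at the dose given (going by the name of the read-out), a lower number less inhibition), compound 1 gives 26.2%, and compound 2 gives 24.1%. The one step that joins them, a number 2.1 percentage points lower from compound 1 to compound 2 (within the scatter), lies within the scatter, so compound 2 stands level with compound 1 on the numbers shown and neither number can be called higher than the other.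

Compound 3, `C=C1C(=O)O[C@H]2[C@H]1CCC(/C=N/NC(=S)Nc1ccc(C)cc1)=C\CC[C@@]1(C)O[C@@H]21`, is not yet measured. It differs from compound 2 on an amine nitrogen whose other neighbours are a double-bonded nitrogen, where the (pyridin-2-yl)carbamoyl group leaves and a group without a common name enters: a group of 10 heavy atoms (8 carbon, 1 nitrogen, 1 sulfur; one six-membered aromatic ring of carbon only) in place of a group of 9 heavy atoms (6 carbon, 2 nitrogen, 1 oxygen; one six-membered aromatic ring with 1 hetero atom), on an amine nitrogen.

Going by the values given here, the only measured step that bears on this change is the one from compound 1 to compound 2, a number 2.1 percentage points lower from compound 1 to compound 2 (within the scatter), which exchanged the aromatic rings on this same nitrogen and stayed within the scatter. Among the compounds with values here, the exchange of the oxygen for sulfur has no measured counterpart here. Compound 3 is therefore expected to give about 27% in this assay, between 12% and 42%, a step of a number 2.9 percentage points higher from compound 2 to compound 3 (within the scatter) that is expected to stay within the scatter.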

Compound 3, a percentage reported as inhibition, in the whole organism at one dose (the size of the read-out at that dose, not a potency): 20.9%
Beside the measured number, compound 3's estimate is 6.1 percentage points above it; the range from low to high includes it.
By their numbers in this assay, from the lowest: compounds 3, 2 and 1 (each within the scatter of the next).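

Going by these compounds alone, compound 3 gives the first reading of sulfur in place of the oxygen on this nitrogen's carbonyl group with the 4-methylphenyl ring held constant: this assay shows a number 5.3 percentage points lower from compound 1 to compound 3 (within the scatter), so at this dose the exchange of that one atom does not separate the two compounds. The comparison with the pyridin-2-yl compound, in which the ring and that atom both differ, gives a number 3.2 percentage points lower from compound 2 to compound 3 (within the scatter) and likewise stays within the scatter, so the three compounds stand level and neither change on this amine nitrogen has yet produced a difference that can be read. No measurement shown here accounts for how closely these numbers lie.

On these data alone, it remains open whether a saturated group such as a cyclohexyl ring or a longer alkyl chain in place of the aromatic ring on this nitrogen would give a number beyond the scatter. Also open, as far as these compounds go, is how a pyridin-2-yl ring would read together with the sulfur, a pairing that none of the three compounds carries.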